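From Carboxy to Sulfamoyl: Expecting Compound 4

The source may hold more compounds than are shown below. What is called first, only, known or untested is meant among the compounds shown, and "the series" means these compounds.

Of the compounds shown here, three sharing one core have been tested in an assay on THP-1 cells for inhibition of nuclear factor NF-kappa-B complex (Homo sapiens), with stated times of 2 h and 16 h; a higher number here means a weaker inhibitor, a lower number a stronger inhibitor. Compound 1 `COc1cccc(OCCC(C)(C)C)c1C(=O)/C=C/c1ccc(O)cc1` reaches only the limit of > 30000 nM in this assay, so no number is known for it. Compound 3 `CC(C)(C)CCOc1cccc(O)c1C(=O)CCc1ccc(O)cc1` likewise stops at the limit of > 30000 nM in this assay. For the measured compounds named here, compound 2 `CC(C)(C)CCOc1cccc(O)c1C(=O)/C=C/c1ccc(C(=O)O)cc1`, which carries a carboxy group on its far ring, gives 2800 nM in this assay, the only actual number among the three; the other two sit at the limit of > 30000 nM in this assay, at which 2 of the 3 values shown sit. Going by the values given here, no two measured compounds differ in a single place, so nothing can be said about how much any one change moved the read-out.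

Compound 4 `CC(C)(C)CCOc1cccc(O)c1C(=O)/C=C/c1ccc(S(N)(=O)=O)cc1` differs from compound 2 in one place: sulfamoyl in place of carboxy on an aromatic carbon. Judged against compound 2 at 2800 nM, a step of modest size is expected, in the direction of weaker inhibition, though it may not clear the usual scatter. Compound 4 is estimated at 5000 nM in this assay, with a likely range from 1500 nM to 20000 nM. The expected step is a 1.8-fold higher number from compound 2 to compound 4 (0.25 log units; within the scatter), with some chance that only a limit is reported.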

Compound 4, half-maximal inhibitory concentration: 1200 nM
Estimate against measurement, compound 4: 4.2-fold (0.62 log units) above; measured number below the stated range.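

In this assay, for the compounds shown here, sulfamoyl in place of carboxy on an aromatic carbon, para to a large group, gives a 2.3-fold lower number from compound 2 to compound 4 (0.37 log units; beyond the scatter) and is the first change on the shared core whose size can be read. For this pair, a carboxy group is therefore not needed at this position to give a measured number, and the sulfamoyl group gives the stronger inhibition, although the two compounds alone cannot show which difference between the groups matters. Compound 1 and compound 3 each differ from the others in more than one place and each reaches only a limit, so steps involving them cannot be read, because just two compounds give actual numbers: the limit of > 30000 nM in this assay, at which 2 of the 4 values shown sit.

Going by these compounds alone, with only one group exchanged at this position, it remains open whether the gain is specific to sulfamoyl or would also appear with a methylsulfonyl group, a tetrazole ring or an amine. On these data alone, it is also open whether the same exchange would have a similar effect on a compound with a different chain on the shared core, such as a shorter alkyl ether.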